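Working notes: from compound 2 to compound 3

The source may report more compounds than this note shows. Statements on the series, on what has been measured and on what is new or still open speak of the compounds shown alone.

In a functional assay on HCT-116 cells (Homo sapiens) for inhibition (on this read-out higher numbers stand for weaker inhibition and lower numbers for stronger inhibition), compound 1 `CCCN(CCC)Cc1cc(-c2c(C(=O)NCC)noc2-c2cc(C(C)C)c(O)cc2O)on1` gives 183 nM and compound 2 `CCNC(=O)c1noc(-c2cc(C(C)C)c(O)cc2O)c1-c1cc(CN2CCCCC2)no1` gives 93 nM. These two values lie within the scatter of each other, so compound 2 cannot be separated from compound 1. Compound 3 `CCNC(=O)c1cc(-c2c(C(=O)NCC)noc2-c2cc(C(C)C)c(O)cc2O)on1` differs from compound 2 as follows: ethylcarbamoyl in place of (piperidin-1-yl)methyl on an aromatic carbon. This places ethylcarbamoyl in place of (piperidin-1-yl)methyl on an aromatic carbon. Among the compounds with values here, the only measured step, a 2.0-fold lower number from compound 1 to compound 2 (0.29 log units; within the scatter), exchanges dipropylamino for piperidin-1-yl on the saturated chain carbon and bears only indirectly on this change. Within the data shown here, no measured compound carries ethylcarbamoyl at this place, so the data fix no firm direction. The expected step is a 1.6-fold higher number from compound 2 to compound 3 (0.21 log units; within the scatter), with no clear shift beyond the scatter and a slight lean towards a higher number. Compound 3 is estimated at 150 nM, with an expected range from 40 nM to 550 nM.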

Compound 3, half-maximal inhibitory concentration: 14 nM
The estimate for compound 3 lay 11-fold (1.03 log units) above the measured number; the whole stated range lies above it.
By their numbers in this assay, from the lowest: compound 3; then compounds 2 and 1 (each within the scatter of the next).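

In this assay, ethylcarbamoyl in place of (piperidin-1-yl)methyl gives a 6.6-fold lower number from compound 2 to compound 3 (0.82 log units; beyond the scatter), and ethylcarbamoyl in place of (dipropylamino)methyl gives a 13-fold lower number from compound 1 to compound 3 (1.12 log units; beyond the scatter). The earlier exchange of one amine for the other on the saturated chain carbon stayed within the scatter, whereas these steps show that replacing the whole group on this aromatic carbon moves the number beyond the scatter. No measurement here explains this shift.

Each step removes the amine and brings in the carbonyl and the hydrogen-bond donor together, so the compounds shown cannot assign the shift to any one of these features. They also leave open how a carboxylic acid, a primary carboxamide or a longer chain on the amide nitrogen would read at this place.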